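The compounds below may be only part of what the source reports. "The series", "measured", "known", "first", "only" and "open" are said of these compounds alone.

Measured compounds:
Compound 1 `C=CCn1c(SCC(=O)c2ccccc2)nnc1-c1ccccc1`: in a functional assay on the whole organism (strain albino) for inhibition, with Rattus norvegicus as the target, read by paw edema, with a stated time of 2 h, at a dose of 0.28 mmol/kg by the oral route (on this read-out higher numbers stand for more inhibition at the one dose given (going by the name of the read-out) and lower numbers for less inhibition), compound 1 gives 58%.
Compound 2 `CCn1c(SCC(=O)c2ccccc2)nnc1-c1ccccc1`: in this assay compound 2 gives 55%.
Compound 3 `CCn1c(SC/C(=N/O)c2ccccc2)nnc1-c1cc(OC)c(OC)c(OC)c1`: in this assay compound 3 gives 67%.

Compound 2 and compound 1 share one core and differ only by vinyl in place of methyl on a saturated chain carbon bound to an aromatic nitrogen. In this assay that change gave a number 3 percentage points higher from compound 2 to compound 1 (within the scatter), so within this pair it made no difference that can be separated from repeat scatter.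

Compound 3 carries a different core; the difference between the two cores is not broken down here. Its value stands above that of compound 1 by a gap inside the scatter and above that of compound 2 by a gap beyond it, so only against compound 2 is the ordering secure.

Compound 4 `C=CCn1c(SC/C(=N/O)c2ccccc2)nnc1-c1cc(OC)c(OC)c(OC)c1` is not yet measured. It differs from compound 3 by vinyl in place of methyl on a saturated chain carbon bound to an aromatic nitrogen, the same change, at the same place, as that from compound 2 to compound 1. Within the data shown here, for compound 4 a step of a number 3 percentage points higher from compound 3 to compound 4 (within the scatter) is expected in this assay, of about the size seen as a number 3 percentage points higher from compound 2 to compound 1 (within the scatter), since that is the only measured instance of the change. On that basis compound 4 is estimated at 70%, with a likely range from 58% to 80%, pending the measurement.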

Compound 4, a percentage reported as inhibition, in the whole organism at one dose (the size of the read-out at that dose, not a potency): 68%
Compound 4: the middle estimate sits 2 percentage points above what was measured; the measured number falls inside the stated range.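

In this assay the swap of ethyl to allyl gave a number 1 percentage points higher from compound 3 to compound 4 (within the scatter), so on this core too the swap cannot be separated from repeat scatter. The two steps on the two cores agree: the same change on two cores in this assay, a number 3 percentage points higher (within the scatter) from compound 2 to compound 1 and a number 1 percentage points higher (within the scatter) from compound 3 to compound 4, 2 percentage points apart, within the scatter of two such steps. This shows that the swap stays without a separable effect on both cores, but it does not show that any real effect carries over, since neither step stands clear of the scatter, and two cores read at one dose and one time say nothing about other cores in the series.

The compounds shown carry only ethyl and allyl at this place, so it remains open whether a longer chain such as butyl, a benzyl group or a chain ending in an amine would give a step beyond the scatter in this assay. Also open, going by these compounds, is whether the same swap stays silent on a core bearing a carboxylic acid.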